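Dropping the Hydroxy Group from Compound 2

A few compounds are considered here, and "the series" means these few. Any claim that something is new, unique, unknown or untested is made for them only; others in the source may bear on it.

Of the compounds shown here, three sharing one core have been measured in an assay on isolated protein for inhibition of Amine oxidase [flavin-containing] A (Rattus norvegicus); on this read-out lower numbers stand for stronger inhibition and higher numbers for weaker inhibition. Compound 1 `C#CCNCc1cc2ccccc2n1C` gives 240 nM. Compound 2 `C#CCN(C)Cc1cc2cc(O)ccc2n1C` gives 3.98 nM, the lowest of the three numbers. Compound 3 `C#CCNCc1cc2cc(O)ccc2n1C` gives 3980 nM. Compound 2 and compound 3 differ by methyl in place of hydrogen on an amine nitrogen, and this change gives a 1000-fold higher number from compound 2 to compound 3 (3.00 log units; beyond the scatter). Compound 3 and compound 1 differ by hydrogen in place of hydroxy on an aromatic carbon, and this change gives a 17-fold lower number from compound 3 to compound 1 (1.22 log units; beyond the scatter). Compound 4 `C#CCN(C)Cc1cc2ccccc2n1C` has not yet been measured. Within the data shown here, it differs from compound 2 by hydrogen in place of hydroxy on an aromatic carbon, the same change as the one from compound 3 to compound 1, at the same place. For compound 4 a step of about a 13-fold lower number from compound 2 to compound 4 (1.12 log units; beyond the scatter) is expected. This expectation rests on a 17-fold lower number from compound 3 to compound 1 (1.22 log units; beyond the scatter), and it agrees with compound 1, whose 240 nM taken together with a 1000-fold higher number from compound 2 to compound 3 (3.00 log units; beyond the scatter) points to the same region. Whether the two changes add up fully when combined is not known, so the range is kept wide. Compound 4 is therefore estimated at 0.3 nM, expected to fall between 0.05 nM and 1.5 nM.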

Compound 4, inhibition constant: 0.302 nM
For compound 4 the middle estimate is 1.0-fold (0.00 log units) below the measured one; measured number inside the range.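

In this assay, hydrogen in place of hydroxy on an aromatic carbon gives a 13-fold lower number from compound 2 to compound 4 (1.12 log units; beyond the scatter), and this step matches the earlier one on the core that lacks the methyl on the amine nitrogen: the same change on two cores in this assay, a 17-fold lower number (1.22 log units; beyond the scatter) from compound 3 to compound 1 and a 13-fold lower number (1.12 log units; beyond the scatter) from compound 2 to compound 4, 1.3-fold (0.10 log units) apart, within the scatter of two such steps. Methyl in place of hydrogen on the amine nitrogen gives a 790-fold lower number from compound 1 to compound 4 (2.90 log units; beyond the scatter), and this step likewise holds whether or not the hydroxy is present: the same change on two cores in this assay, a 1000-fold higher number (3.00 log units; beyond the scatter) from compound 2 to compound 3 and a 790-fold higher number (2.90 log units; beyond the scatter) from compound 4 to compound 1, 1.3-fold (0.10 log units) apart, within the scatter of two such steps. Within these four compounds, each change therefore carries from one core to the other and the two changes add up, but each comparison rests on just one pair of cores, so this does not show that either step would keep its size on any other core, nor why the steps are so large.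

The compounds shown leave open what a methoxy group or a fluorine atom would do in place of the hydroxy. They also leave open whether an ethyl group or a longer chain on the amine nitrogen would act as the methyl does.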